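The source may report more compounds than this note shows. Statements on the series, on what has been measured and on what is new or still open speak of the compounds shown alone.

Of the compounds shown here, three built on a shared core have been measured in a functional assay on HepG2 cells (Homo sapiens) for inhibition, read by MTT assay, with a stated time of 48 h (on this read-out lower numbers stand for stronger inhibition and higher numbers for weaker inhibition), and they differ only in the group attached to the carbonyl carbon of an amide. Compound 1 `CCC(=O)Nc1ccc(N2CCN(c3ccc(OC[C@@H]4CO[C@@](Cn5cncn5)(c5ccc(Cl)cc5Cl)O4)cc3)CC2)cc1` gives 5460 nM in this assay, the lowest of the three numbers. Compound 2 `O=C(CCCc1ccccc1)Nc1ccc(N2CCN(c3ccc(OC[C@@H]4CO[C@@](Cn5cncn5)(c5ccc(Cl)cc5Cl)O4)cc3)CC2)cc1` gives 10800 nM, and the change a 2.0-fold higher number from compound 1 to compound 2 (0.30 log units; within the scatter) lies within the scatter. Compound 3 `O=C(Nc1ccc(N2CCN(c3ccc(OC[C@@H]4CO[C@@](Cn5cncn5)(c5ccc(Cl)cc5Cl)O4)cc3)CC2)cc1)c1ccco1` gives 22300 nM, and the step of a 4.1-fold higher number from compound 1 to compound 3 (0.61 log units; beyond the scatter) is beyond the scatter, as is a 2.1-fold higher number from compound 2 to compound 3 (0.31 log units; beyond the scatter).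

Compound 4 `Cc1ccc(C(=O)Nc2ccc(N3CCN(c4ccc(OC[C@@H]5CO[C@@](Cn6cncn6)(c6ccc(Cl)cc6Cl)O5)cc4)CC3)cc2)o1` has not yet been measured. It differs from compound 1 by 5-methylfuran-2-yl in place of ethyl on a carbonyl carbon. The closest guide is the step from compound 1 to compound 3, where a furan-2-yl also replaced ethyl and the number rose by a 4.1-fold higher number from compound 1 to compound 3 (0.61 log units; beyond the scatter). Compound 4 carries the same ring with a methyl added, and nothing measured here shows what that methyl does. The expectation is therefore a rise of about the size seen for compound 3, and the estimated step is a 3.7-fold higher number from compound 1 to compound 4 (0.56 log units; beyond the scatter). On that basis compound 4 is expected to give about 20000 nM in this assay, with a likely range from 8000 nM to 50000 nM.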

Compound 4, half-maximal inhibitory concentration: 8700 nM
Compound 4: middle estimate off by 2.3-fold (0.36 log units), on the high side, within the range that was stated.
By their numbers in this assay, from the lowest: compounds 1, 4 and 2 (each within the scatter of the next); then compound 3.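

Within the data shown here, putting a methyl in place of hydrogen on an aromatic carbon of the furan-2-yl group gives a 2.6-fold lower number from compound 3 to compound 4 (0.41 log units; beyond the scatter) in this assay and so shows, for the first time here, that a small change on the ring itself can shift the result beyond the scatter. The ring as such therefore does not fix the number, since compound 4 carries the same ring as compound 3 yet shows a 1.6-fold higher number from compound 1 to compound 4 (0.20 log units; within the scatter) and also a 1.2-fold lower number from compound 2 to compound 4 (0.09 log units; within the scatter) and thus cannot be told apart from either chain compound. Among these four compounds, only compound 3 stands apart from all the others, and no measurement shown here explains what the added methyl does.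

A single methyl on a single ring leaves open whether an ethyl or a chlorine in place of that methyl would give a similar number. From the compounds shown here alone, it also remains open whether the result would hold for a different ring on the carbonyl carbon, such as thiophen-2-yl or a plain phenyl, with or without a methyl.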